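Trifluoromethyl swapped on the weakest compound of the series

The source may hold more compounds than are shown below. What is called first, only, known or untested is meant among the compounds shown, and "the series" means these compounds.

In a functional assay on A549 cells (Homo sapiens) for inhibition, read by CCK-8 assay, with a stated time of 48 h (a lower number here means a stronger inhibitor, a higher number a weaker inhibitor), compound 1 (`COc1cc(-c2ccnc3cc(-c4c[nH]c5ccccc45)nn23)cc(OC)c1OC`) gives 29 nM and compound 2 (`COc1cc(-c2ccnc3cc(-c4ccc5c(ccn5C)c4)nn23)cc(OC)c1OC`) gives 15 nM on the same core. The step is a 1.9-fold lower number from compound 1 to compound 2 (0.29 log units; within the scatter) and gives no ranking. Compound 3 (`COc1cc(-c2ccnc3cc(-c4ccc(C(F)(F)F)cc4)nn23)cc(OC)c1OC`) gives 2070 nM and stands as the weakest of the three. The steps of a 71-fold higher number from compound 1 to compound 3 (1.85 log units; beyond the scatter) and a 140-fold higher number from compound 2 to compound 3 (2.14 log units; beyond the scatter) set it well apart.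

Compound 4 (`COc1cc(-c2ccnc3cc(-c4ccc(-c5cnn(C)c5)cc4)nn23)cc(OC)c1OC`) carries 1-methyl-1H-pyrazol-4-yl in place of trifluoromethyl on an aromatic carbon. Going by the values given here, no measured compound holds this group, and no measured step changes the trifluoromethyl alone. The two large steps replace the whole aryl group, so they bear only indirectly, but they show that this group can move the number a long way. Compounds 1 and 2 both carry indolyl groups, and compound 4 also brings more than one ring to this place, so partial recovery is expected rather than a full return. The step expected in this assay is a 6.9-fold lower number from compound 3 to compound 4 (0.84 log units; beyond the scatter) as an estimate, toward a lower number and with wide uncertainty. The estimated value for compound 4 is 300 nM (expected range 50 nM to 2000 nM).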

Compound 4, half-maximal inhibitory concentration: 1150 nM
Beside the measured number, compound 4's estimate is 3.8-fold (0.58 log units) below it; the range from low to high includes it.
By their numbers in this assay, from the lowest: compounds 2 and 1 (each within the scatter of the next); then compounds 4 and 3 (each within the scatter of the next).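

In this assay the exchange of trifluoromethyl for 1-methyl-1H-pyrazol-4-yl, on an aromatic carbon para to a large group, gives no ranking (a 1.8-fold lower number from compound 3 to compound 4 (0.26 log units; within the scatter)). Going by these compounds alone, this is the first change confined to the substituent on the phenyl ring, and replacing a group with no ring and no hydrogen-bond acceptors by an aromatic ring that has hydrogen-bond acceptors leaves compounds 3 and 4 together in the upper pair of numbers, where compound 4 gives 1150 nM and compound 2 gives 15 nM, so extending the phenyl group with this ring does not reach the range of the two indolyl compounds. No available evidence bears on the reason for this result.

From the compounds shown here alone, it remains open whether any group at this place can separate from trifluoromethyl, for example an amine such as morpholin-4-yl, a carboxylic acid or a longer alkoxy chain. Also open, going by these compounds, is whether the phenyl ring itself, with hydrogen in place of trifluoromethyl, would give a number nearer those of the indolyl compounds or of this pair.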